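This account rests on a few compounds, and the source may have more. Where it says the series, first, only, none or still open, it means among the compounds named here.

Of the compounds shown here, three have so far been tested in a functional assay on HEK293 cells (Homo sapiens) for inhibition; a lower number here means a stronger inhibitor, a higher number a weaker inhibitor. Compound 1 (`CCCCCCCCCCS(=O)(=O)NCCCNCCCNCCCCNCCCNCCCNS(=O)(=O)CCCCCCCCCC`) gives 4200 nM, and compound 2 (`CCCCCCCCCCCCCCCCCCS(=O)(=O)NCCCNCCCNCCCCNCCCNCCCNS(=O)(=O)CCCCCCCCCCCCCCCCCC`) gives 6490 nM. Compound 3 (`CCCCCCCCCCCCCCCCS(=O)(=O)NCCCN(CCCNCCCCNCCCN)CCCNS(=O)(=O)CCCCCCCCCCCCCCCC`) gives 4850 nM, which lies within the scatter of both other values, so the three cannot be ranked on these numbers.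

Compound 4 (`CCCCCCCCCCCCCCCCS(=O)(=O)NCCCN(CCCNCCCNCCCCNCCCN)CCCNS(=O)(=O)CCCCCCCCCCCCCCCC`) is yet to be measured. It departs from compound 3 at one place: (4-((3-aminopropyl)amino)butyl)amino in place of ((3-aminopropyl)amino)methyl on a saturated chain carbon, three bonds along the chain from an amine nitrogen. This places (4-((3-aminopropyl)amino)butyl)amino in place of ((3-aminopropyl)amino)methyl on a saturated chain carbon, three bonds along the chain from an amine nitrogen.

Going by the values given here, no two measured compounds differ in only one place, so no measured step shows what such a change does in this assay. The expectation therefore rests on the narrow spread of the three values, with compound 3 at 4850 nM as the closest reference. No step beyond the scatter is expected, and the estimated change is a 1.1-fold lower number from compound 3 to compound 4 (0.03 log units; within the scatter). For compound 4 the estimated value is 4500 nM, with an expected range of 2400 nM to 8500 nM.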

Compound 4, half-maximal inhibitory concentration: 2680 nM
Estimate against measurement, compound 4: 1.7-fold (0.23 log units) above; the measured number falls inside the stated range.
By their numbers in this assay, from the lowest: compounds 4, 1, 3 and 2 (each within the scatter of the next, the first and the last beyond it).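

In this assay, going by these compounds alone, the exchange of ((3-aminopropyl)amino)methyl for (4-((3-aminopropyl)amino)butyl)amino on a saturated chain carbon, three bonds along the chain from an amine nitrogen, gives the first step that can be read at this position: a 1.8-fold lower number from compound 3 to compound 4 (0.26 log units; within the scatter). The larger group therefore produces no effect that can be told apart from the scatter of the measurement, and this single step shows neither a gain nor a loss from the exchange. No available data bear on this result.

The compounds shown leave open whether a guanidine or a carboxylic acid at the end of this branch would give a step beyond the scatter. They also leave open whether the same exchange would read alike with a dodecyl chain on the sulfonyl groups in place of hexadecyl.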